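A few compounds are considered here, and "the series" means these few. Any claim that something is new, unique, unknown or untested is made for them only; others in the source may bear on it.

In a functional assay on HL60/MX2 cells (Homo sapiens) for antiproliferative activity, read by MTT assay, with a stated time of 48 h (on this read-out higher numbers stand for weaker inhibition and lower numbers for stronger inhibition), compound 1 `CN(C)CCn1c(N)c(-c2nc3cc(Cl)ccc3[nH]2)c2nc(C#N)c(C#N)nc21` gives > 50000 nM, which is a limit of the assay. Within the data shown here, compound 2 `CN(C)CCCn1c(N)c(-c2nc3cc(Cl)ccc3[nH]2)c2nc(C#N)c(C#N)nc21` gives 5310 nM, the only true number so far. Compound 3 `CCN(CC)CCCCn1c(N)c(-c2nc3cc(Cl)ccc3[nH]2)c2nc(C#N)c(C#N)nc21` carries 4-(diethylamino)butyl in place of the 3-(dimethylamino)propyl of compound 2: (diethylamino)methyl in place of dimethylamino on a saturated chain carbon, three bonds along the chain from an aromatic nitrogen. Among the measured compounds shown here, one measured step bears on this, an at least 9.4-fold lower number from compound 1 to compound 2 (0.97 log units; beyond the scatter), and its size rests on (the limit of > 50000 nM in this assay, at which 1 of the 2 values shown sits). A smaller move in the same direction is therefore expected in this assay, and it may stay within the scatter: a 1.9-fold lower number from compound 2 to compound 3 (0.28 log units; within the scatter). For compound 3 the estimated value is 2800 nM, with an expected range of 800 nM to 12000 nM.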

Compound 3, half-maximal inhibitory concentration: 1770 nM
Estimate against measurement, compound 3: 1.6-fold (0.20 log units) above; the range from low to high includes it.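

Two true numbers now give a 3.0-fold lower number from compound 2 to compound 3 (0.48 log units; beyond the scatter) in this assay, so the direction of change at this chain no longer rests on a limit alone. Going from 2-(dimethylamino)ethyl to 4-(diethylamino)butyl gives an at least 28-fold lower number from compound 1 to compound 3 (1.45 log units; beyond the scatter), a step whose size is open-ended: the limit of > 50000 nM in this assay, at which 1 of the 3 values shown sits.

The step from 3-(dimethylamino)propyl to 4-(diethylamino)butyl alters chain length and the groups on the amine together, so the compounds shown cannot separate the two. A 4-(dimethylamino)butyl or 3-(diethylamino)propyl chain would divide these contributions, and a longer chain or a morpholine end would test how far the trend extends.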